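Trifluoromethyl in place of cyclopropyl on a shared core

The source may report more compounds than this note shows. Statements on the series, on what has been measured and on what is new or still open speak of the compounds shown alone.

Of the compounds shown here, three sharing one core have been measured in a physicochemical assay for lipophilicity, read by LC-MS; a higher number here means a more lipophilic compound, a lower number a more polar compound. Compound 1 `FC(F)(F)c1nccc(N[C@H]2CC[C@@H](Nc3ccc4nncn4n3)CC2)n1`, with hydrogen at the carbon that varies, gives 1.7. Compound 2 `FC(F)(F)c1nccc(N[C@H]2CC[C@@H](Nc3ccc4nnc(Br)n4n3)CC2)n1`, with bromo there, gives 2.9. Compound 3 `FC(F)(F)c1nccc(N[C@H]2CC[C@@H](Nc3ccc4nnc(C5CC5)n4n3)CC2)n1`, with cyclopropyl, gives 4.5, the highest number of the three.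

Compound 4 `FC(F)(F)c1nccc(N[C@H]2CC[C@@H](Nc3ccc4nnc(C(F)(F)F)n4n3)CC2)n1` has not yet been measured. It differs from compound 3 in one place: trifluoromethyl in place of cyclopropyl on an aromatic carbon. In words, trifluoromethyl stands in place of cyclopropyl on an aromatic carbon.

Three measured steps at this carbon bear on the change, and all are large: a number 1.20 log units higher from compound 1 to compound 2 (beyond the scatter), a number 2.80 log units higher from compound 1 to compound 3 (beyond the scatter) and a number 1.60 log units higher from compound 2 to compound 3 (beyond the scatter). None involves trifluoromethyl, so the comparison is indirect. Compound 2 is taken as the closest guide, since its group also carries halogen, and a large fall of somewhat smaller size than a number 1.60 log units higher from compound 2 to compound 3 (beyond the scatter) is therefore expected in this assay. The expected step is a number 1.30 log units lower from compound 3 to compound 4 (beyond the scatter). Compound 4 is estimated at 3.2, with an expected range from 2.6 to 3.9.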

Compound 4, distribution coefficient: 3.8
The estimate for compound 4 lay 0.60 log units below the measured number; measured number inside the range.
By their numbers in this assay, from the lowest: compound 1; then compound 2; then compound 4; then compound 3.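

In this assay trifluoromethyl at this carbon falls apart from both groups already tried there, with a number 0.90 log units higher from compound 2 to compound 4 (beyond the scatter) and a number 0.70 log units lower from compound 3 to compound 4 (beyond the scatter) so that it takes an intermediate place between bromo and cyclopropyl. Set against hydrogen, the same group gives a number 2.10 log units higher from compound 1 to compound 4 (beyond the scatter) and so joins bromo and cyclopropyl in raising the number at this position. Trifluoromethyl carries more heavy atoms than cyclopropyl yet gives the lower number, so heavy-atom count alone does not order this pair. No measurement offered here explains the order of these groups.

The compounds shown leave open where an amine, a carboxylic acid or a methoxy group at this carbon would fall on this scale. They also leave open whether a longer chain in place of cyclopropyl would exceed compound 3.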